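A few compounds are considered here, and "the series" means these few. Any claim that something is new, unique, unknown or untested is made for them only; others in the source may bear on it.

Measured compounds:
- compound 1, `CCN(Cc1ccncc1)C(=S)SCc1ccc(C(=O)Nc2ccccc2N)cc1` — 86.2% in a functional assay on A-375 cells (Homo sapiens) for antiproliferative activity, read by CCK-8 assay, with a stated time of 72 h, tested at 8 uM; on this read-out higher numbers stand for a stronger effect at the one concentration tested and lower numbers for a weaker effect
- compound 2, `Nc1ccccc1NC(=O)c1ccc(CSC(=S)N2CCN(Cc3ccncc3)CC2)cc1` — 89.5%
- compound 3, `Nc1ccccc1NC(=O)c1ccc(CSC(=S)N2CCc3cc([N+](=O)[O-])ccc32)cc1` — 29.5%

All three share the same core and differ only in the amine attached to the thiocarbonyl. In this assay compound 2 gives 89.5%; compound 1, giving 86.2%, lies within the usual scatter of that figure, so the two cannot be told apart on these numbers. Compound 3, giving 29.5%, lies far below both, well beyond the scatter.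

Compound 4, `Nc1ccccc1NC(=O)c1ccc(CSC(=S)N2CCN(Cc3ccccc3)CC2)cc1`, has not yet been measured. It differs from compound 2 in one place: phenyl in place of pyridin-4-yl on a saturated chain carbon bound to an amine nitrogen in a ring. The ring-bound amine and the rest of the molecule stay as in compound 2. Because compound 2 gives 89.5% and compound 1, with a different amine but the same (pyridin-4-yl)methyl group, gives 86.2%, the readout appears tolerant at this position, and no change beyond the scatter is expected in this assay, or at most a small fall (a number 5.5 percentage points lower from compound 2 to compound 4 (within the scatter)). Compound 4 is expected to give 84%, within a range from 65% to 95%.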

Compound 4, a percentage reported as inhibition, at one concentration (the size of the read-out at that concentration, not a potency): 29.3%
Compound 4: middle estimate off by 54.7 percentage points, on the high side, and the stated range ends above it.
By their numbers in this assay, from the lowest: compounds 4 and 3 (each within the scatter of the next); then compounds 1 and 2 (each within the scatter of the next).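

Measured by this assay the change from pyridin-4-yl to phenyl on this saturated chain carbon gives a number 60.2 percentage points lower from compound 2 to compound 4 (beyond the scatter) and so shows that this position does not accept every six-membered aromatic ring. The two groups have the same number of heavy atoms; the computed difference is that a ring nitrogen, which counts as the one hydrogen-bond acceptor of pyridin-4-yl, is replaced by carbon. The data shown give no measurement that accounts for this fall.

From the compounds shown here alone, it remains open whether a pyridin-3-yl or pyridin-2-yl group on the same carbon would keep the higher read-out of compound 2 or fall towards that of compound 4. Going by these compounds, it is also open whether benzyl in place of (pyridin-4-yl)methyl would cause a similar fall on the amine of compound 1.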